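The source may report more compounds than this note shows. Statements on the series, on what has been measured and on what is new or still open speak of the compounds shown alone.

In an assay on isolated protein for inhibition of protein deacetylase HDAC6 (Homo sapiens), read by fluorescence, with a stated time of 1 h, tested at 100 nM (on this read-out lower numbers stand for less inhibition and higher numbers for more inhibition at the one concentration tested (going by the name of the read-out)), compound 3 `O=C(/C=C/c1ccc(OCc2nc(C3CCN(Cc4ccccc4Cl)CC3)no2)cc1)NO` gives 59%, the smallest of the three numbers, though compound 2 `O=C(/C=C/c1ccc(OCc2nc(C3CCN(Cc4ccc(F)c(F)c4)CC3)no2)cc1)NO` at 60% is separated from it only by a number 1 percentage points lower from compound 2 to compound 3 (within the scatter), which lies within the scatter; compound 1 `Cc1cccc(CN2CCC(c3noc(COc4ccc(/C=C/C(=O)NO)cc4)n3)CC2)c1` at 73% stands clearly apart, by a number 14 percentage points lower from compound 1 to compound 3 (beyond the scatter).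

Compound 4 `O=C(/C=C/c1ccc(OCc2nc(C3CCN(Cc4ccc(Br)cc4)CC3)no2)cc1)NO` differs from compound 3 in one place: 4-bromophenyl in place of 2-chlorophenyl on a saturated chain carbon bound to an amine nitrogen in a ring.

Among the compounds with values here, the steps that bear on this are those among the three benzyl variants: a number 13 percentage points lower from compound 1 to compound 2 (beyond the scatter) and a number 14 percentage points lower from compound 1 to compound 3 (beyond the scatter) both modest, while a number 1 percentage points lower from compound 2 to compound 3 (within the scatter), a halogenated phenyl for another, did not leave the scatter. A halogen-for-halogen exchange is therefore expected to yield no step beyond the scatter, a number 1 percentage points higher from compound 3 to compound 4 (within the scatter). Compound 4 is estimated at 60%, between 48% and 72%.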

Compound 4, a percentage reported as inhibition, at one concentration (the size of the read-out at that concentration, not a potency): 58%
Compound 4: the middle estimate sits 2 percentage points above what was measured; measured number inside the range.
By their numbers in this assay, from the lowest: compounds 4, 3 and 2 (each within the scatter of the next); then compound 1.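

In this assay, the 4-bromophenyl group matches the other halogenated phenyl groups, with a number 1 percentage points lower from compound 3 to compound 4 (within the scatter) and a number 2 percentage points lower from compound 2 to compound 4 (within the scatter), so compound 2, compound 3 and compound 4 form one level that does not separate these halogenated phenyl groups. The 3-methylphenyl group stays apart from this level, with a number 15 percentage points lower from compound 1 to compound 4 (beyond the scatter), now against three halogenated phenyl groups rather than two. Nothing available explains this gap. Open, from the compounds shown here alone, is how an unsubstituted phenyl, a methoxyphenyl or an aminophenyl would read at this place. Going by these compounds, a carboxylic acid on the ring also remains open.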